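A few compounds are considered here, and "the series" means these few. Any claim that something is new, unique, unknown or untested is made for them only; others in the source may bear on it.

The measured compounds, each with its value in a functional assay on MT4 cells (Homo sapiens) for cytotoxicity, read by MTT assay, with a stated time of 5 days; on this read-out higher numbers stand for lower toxicity in this test and lower numbers for higher toxicity in this test: compound 1, `N#Cc1ccc(Nc2nccc(Nc3ccc(-c4ccc(C#N)cc4)cc3F)n2)cc1`, gives 308000 nM. Compound 2, `COc1cc(Nc2ccnc(Nc3ccc(C#N)cc3)n2)ccc1-c1ccc(C#N)cc1`, gives 5260 nM. Compound 3, `N#Cc1ccc(Nc2nccc(Nc3ccc(-c4ccc(C#N)cc4)c(F)c3)n2)cc1`, gives > 271000 nM, which is a limit of the assay and not a number.

Compound 3 therefore stands at the limit of > 271000 nM in this assay, at which 1 of the 3 values shown sits. Among the compounds with values here, of the measured steps only one bears on the change at hand: an at least 51-fold higher number from compound 2 to compound 3 (1.71 log units; beyond the scatter), which shows that exchanging the group at this place on the ring moves the read-out strongly. Within the data shown here, compound 1 carries its fluoro elsewhere and has no single-change step to the others, so it only sets a second high value alongside compound 3.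

Compound 4, `Cc1cc(Nc2ccnc(Nc3ccc(C#N)cc3)n2)ccc1-c1ccc(C#N)cc1`, differs from compound 3 by methyl in place of fluoro on an aromatic carbon. Among the measured compounds shown here, the methyl of compound 4 is neither the methoxy of compound 2 nor the fluoro of compound 3, and no measured pair shows a methyl at this place. Given an at least 51-fold higher number from compound 2 to compound 3 (1.71 log units; beyond the scatter), compound 4 is expected to fall between compound 2 and compound 3 in this assay, and the step of an at least 6.7-fold lower number from compound 3 to compound 4 (0.83 log units; beyond the scatter) is the expected change. Compound 4 is thus estimated at 40000 nM, with a range from 6000 nM to 300000 nM.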

Compound 4, half-maximal cytotoxic concentration: 12400 nM
The estimate for compound 4 lay 3.2-fold (0.51 log units) above the measured number; measured number inside the range.
By their numbers in this assay, from the lowest: compound 2; then compound 4; then compound 1.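

In this assay, the new compound shows that the high number at this place, on the aromatic carbon ortho to a 4-cyanophenyl group, does not extend to every small group: methyl in place of fluoro gives an at least 21-fold lower number from compound 3 to compound 4 (1.33 log units; beyond the scatter). Methyl in place of methoxy gives only a 2.4-fold higher number from compound 2 to compound 4 (0.37 log units; beyond the scatter), a modest step though beyond the scatter, so among the three groups shown here, fluoro alone goes with a high number. The value of compound 3 remains a limit of the assay and not a number, so the large step from it has only a lower bound: the limit of > 271000 nM in this assay, at which 1 of the 4 values shown sits.

Going by these compounds, whether the high number belongs to fluoro alone stays open, since chloro, hydroxyl, an amine or a longer chain such as ethyl at this place would show whether other groups share it, and the true size of the step to compound 3 is also unsettled. Within the data shown here, compound 1 has no single-change step to the other compounds, so the effect of moving the fluoro to its other place on the ring cannot be read from these values.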